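The source may report more compounds than this note shows. Statements on the series, on what has been measured and on what is new or still open speak of the compounds shown alone.

Measured so far:
compound 1 `O=C1/C(=C\c2ccc(F)cc2)c2ccccc2N1c1c(Cl)cccc1Cl` gives 5 ug/mL
compound 2 `CN(C)c1ccc(/C=C2\C(=O)N(c3c(Cl)cccc3Cl)c3ccccc32)cc1` gives 15 ug/mL

Both values come from a functional assay on KB cells (Homo sapiens) for cytotoxicity, read by MTT assay, with a stated time of 72 h; on this read-out lower numbers stand for an effect already at smaller amounts and higher numbers for an effect only at larger amounts of compound. Compound 2 stands at the higher of the two numbers; its nearest neighbour is compound 1, and the step of a 3.0-fold higher number from compound 1 to compound 2 (0.48 log units; beyond the scatter) separates them. Compound 3 `COc1ccc(/C=C2\C(=O)N(c3c(Cl)cccc3Cl)c3ccccc32)cc1` is not yet measured in this assay. It differs from compound 2 by methoxy in place of dimethylamino on an aromatic carbon.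

For the measured compounds named here, only one measured step bears on this change, and only loosely: the step from compound 1 to compound 2 replaced fluoro by dimethylamino at the same aromatic carbon and raised the number in a modest but clear way. Methoxy is neither of those two groups, so the direction of the step to compound 3 cannot be read off directly. Because the dimethylamino compound 2 sits at 15 ug/mL while the fluoro compound 1 sits at 5 ug/mL, a number for compound 3 somewhere between the two, or close to compound 2, is expected. The estimated step is a 1.9-fold lower number from compound 2 to compound 3 (0.27 log units; within the scatter). Compound 3 is therefore estimated at 8 ug/mL, with a range from 3 ug/mL to 20 ug/mL.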

Compound 3, concentration for half-maximal effect: > 100 ug/mL
Compound 3 ended at the assay's limit; the forecaster's own chance of this, stated with the estimate: 5%; middle value at least 12-fold (1.09 log units) from the limit.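

For the compounds shown here, the first pair of compounds showed only a modest shift at this place, on an aromatic carbon para to a large group, but the new result shows that the choice of group there can do much more in this assay: an at least 6.6-fold higher number from compound 2 to compound 3 (0.82 log units; beyond the scatter), and an at least 20-fold higher number from compound 1 to compound 3 (1.30 log units; beyond the scatter). Dimethylamino and methoxy carry the same counts of hydrogen-bond donors and acceptors and no net charge, so those counts do not separate the two groups, yet swapping one for the other moves the number well beyond the scatter, and among the three groups shown methoxy gives the highest reading. Compound 3 stands at a limit of the assay and not at a number, so both new steps are only lower bounds: the limit of > 100 ug/mL in this assay, at which 1 of the 3 values shown sits.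

How far past that limit compound 3 really lies stays open, and nothing shown explains why two groups so alike in these counts read so differently. As far as these compounds go, it also remains open whether a free hydroxy, a primary amine or a longer chain such as ethoxy at this place would read like methoxy or like dimethylamino.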